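Chain length and cell growth inhibition in one series

The source may report more compounds than this note shows. Statements on the series, on what has been measured and on what is new or still open speak of the compounds shown alone.

Two measured compounds share one core: compound 1 `Nc1ncnc2c1c(-c1cnc3[nH]ccc3c1)nn2CCCCCCCCCC(=O)NO` and compound 2 `Nc1ncnc2c1c(-c1cnc3[nH]ccc3c1)nn2CCCCCCC(=O)NO`. In a functional assay on MDA-MB-231 cells (Homo sapiens) for inhibition, read by MTT assay, with a stated time of 72 h (on this read-out higher numbers stand for weaker inhibition and lower numbers for stronger inhibition), compound 2 gives 37700 nM, and compound 1 gives 10100 nM. For the measured compounds named here, the change between them, (3-(hydroxycarbamoyl)propyl in place of hydroxycarbamoyl on a saturated chain carbon, six bonds along the chain from an aromatic nitrogen), is the only measured instance of this change.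

Compound 3 `Nc1nc2cc(-c3nn(CCCCCC(=O)NO)c4ncnc(N)c34)ccc2o1` carries a different core; how the two cores differ is not broken down here. In this assay compound 3 gives 19000 nM, which stands within the scatter of both compound 1 and compound 2.

Compound 4 `Nc1nc2cc(-c3nn(CCCCCCCCC(=O)NO)c4ncnc(N)c34)ccc2o1` is not yet measured in this assay. It differs from compound 3 by 3-(hydroxycarbamoyl)propyl in place of hydroxycarbamoyl on a saturated chain carbon, five bonds along the chain from an aromatic nitrogen. This is the same kind of change as that made from compound 2 to compound 1, though the place is not the same word for word: there the saturated chain carbon sits six bonds along the chain from an aromatic nitrogen, here five. The expectation rests on a 3.7-fold lower number from compound 2 to compound 1 (0.57 log units; beyond the scatter) and on compound 3 at 19000 nM. Going by the values given here, the step expected from compound 3 to compound 4 is a 2.9-fold lower number from compound 3 to compound 4 (0.47 log units; beyond the scatter), set somewhat below the measured step, as the core and the place differ and only one measured instance exists. Compound 4 is therefore expected to give 6500 nM, with a range from 2500 nM to 16000 nM.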

Compound 4, half-maximal inhibitory concentration: 30300 nM
Compound 4: the middle estimate sits 4.7-fold (0.67 log units) below what was measured; measured number outside the range, above it.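

Putting 3-(hydroxycarbamoyl)propyl in place of hydroxycarbamoyl does not act as one fixed step across the two cores in this assay: the same change on two cores in this assay, a 3.7-fold lower number (0.57 log units; beyond the scatter) from compound 2 to compound 1 and a 1.6-fold higher number (0.20 log units; within the scatter) from compound 3 to compound 4, 6.0-fold (0.77 log units) apart, beyond the scatter of two such steps

On the second core the change gives a 1.6-fold higher number from compound 3 to compound 4 (0.20 log units; within the scatter), so the clear step seen on the first core does not recur there. For the compounds shown here, with a single pair on each core, this shows only that the step cannot be transferred from one core to the other in these four compounds; it does not show why the two steps part, nor how either core behaves at other chain lengths.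

The compounds shown leave open whether a still longer chain or a shorter one would separate the two cores further, since no chain length here is shared by both cores. Also open, as far as these compounds go, is whether a carboxylic acid in place of the hydroxycarbamoyl end would give numbers in the same range on either core.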